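The compounds below may be only part of what the source reports. "The series", "measured", "known", "first", "only" and "open" are said of these compounds alone.

Compound 3 `CC[C@H](C)[C@H](N)CN(C(=O)[C@@H]1C[C@H]1c1ccc(C#N)cc1)c1ccc(-c2ccccc2)cc1` carries a 4-cyanophenyl on the three-membered ring of the shared core. In a functional assay for agonist activity at G protein-coupled receptor 88 (Homo sapiens), read by HTRF and cAMP accumulation (on this read-out higher numbers stand for an effect only at larger amounts of compound and lower numbers for an effect already at smaller amounts), compound 3 gives > 25000 nM, which is a limit of the assay rather than a measured number. Compound 1 `CC[C@H](C)[C@H](N)CN(C(=O)[C@@H]1C[C@H]1c1ccccc1Cl)c1ccc(-c2ccccc2)cc1`, with a 2-chlorophenyl at the same place, also reaches only a limit, giving > 25000 nM in this assay. Compound 2 `CC[C@H](C)[C@H](N)CN(C(=O)[C@@H]1C[C@H]1c1cccc(F)c1)c1ccc(-c2ccccc2)cc1`, with a 3-fluorophenyl, gives 560 nM in this assay. Two of the three values therefore sit at the limit of > 25000 nM in this assay, at which 2 of the 3 values shown sit. The measured steps are an at least 44-fold lower number from compound 1 to compound 2 (1.64 log units; beyond the scatter) and an at least 44-fold higher number from compound 2 to compound 3 (1.64 log units; beyond the scatter), while a step that the two limits leave unreadable from compound 1 to compound 3 cannot be read, since both ends are limits.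

Compound 4 `CC[C@H](C)[C@H](N)CN(C(=O)[C@@H]1C[C@H]1c1c(F)cccc1F)c1ccc(-c2ccccc2)cc1` arises from compound 3 through (2,6-difluorophenyl in place of 4-cyanophenyl on a saturated ring carbon). The steps to and from the 3-fluorophenyl of compound 2 show that this position tolerates some aromatic groups and not others, and a 2,6-difluorophenyl has not been tested. A step of an at least 3.1-fold lower number from compound 3 to compound 4 (0.49 log units; beyond the scatter) is expected, though with little confidence in its size. Compound 4 is estimated at 8000 nM, in a range from 700 nM to 25000 nM, with a real chance that only a limit is recorded.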

Compound 4, half-maximal effective concentration: 11000 nM
Compound 4: the middle estimate sits 1.4-fold (0.14 log units) below what was measured; the range from low to high includes it.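

Putting 2,6-difluorophenyl in place of either group that stopped at a limit of this assay gives a readable value, with an at least 2.2-fold lower number from compound 3 to compound 4 (0.35 log units; beyond the scatter) and an at least 2.2-fold lower number from compound 1 to compound 4 (0.35 log units; beyond the scatter). Having fluorine on the phenyl is not enough to match the 3-fluorophenyl, however: this change gives a 20-fold higher number from compound 2 to compound 4 (1.29 log units; beyond the scatter). The first two steps each start from a limit of the assay, so their true sizes stay unknown: the limit of > 25000 nM in this assay, at which 2 of the 4 values shown sit.

The 3-fluorophenyl and 2,6-difluorophenyl differ both in the number of fluorine atoms and in where those atoms sit, so the compounds shown cannot say which of the two matters here. They also leave open how a phenyl bearing an amine or a carboxylic acid, or a longer chain in place of the phenyl, would behave on this ring carbon.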